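Methyl in place of hydrogen on one aryl ring

The source may report more compounds than this note shows. Statements on the series, on what has been measured and on what is new or still open speak of the compounds shown alone.

Measured compounds in an assay on CHO cells for displacement of a labelled ligand from adenosine receptor A1 (Homo sapiens), read by scintillation counting, with a stated time of 1 h, tested at 1 uM; on this read-out lower numbers stand for less inhibition and higher numbers for more inhibition at the one concentration tested (going by the name of the read-out):
compound 1 `Nc1ncc(-c2ccccc2)c(-c2ccccc2)n1` gives 32%.
compound 2 `Cc1cccc(-c2cnc(N)nc2-c2ccccc2)c1` gives > 80%, which is a limit of the assay and not a number.

For the measured compounds named here, compound 1 stands as the only plain number in this assay; the other value shown for the pair is a limit. Going by the values given here, the one measured step, a number at least 48 percentage points higher from compound 1 to compound 2 (beyond the scatter), is methyl in place of hydrogen on an aromatic carbon; the size of that step is bounded by the limit of > 80% in this assay, at which 1 of the 2 values shown sits, so only its lower bound is known.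

Compound 3 `Cc1ccc(-c2cnc(N)nc2-c2ccccc2)cc1` differs from compound 1 by methyl in place of hydrogen on an aromatic carbon. The change is of the same kind as the measured step, methyl in place of hydrogen on an aromatic carbon, but at a different place on the same ring, so the measured step bears on it only as a guide to direction and rough size. A step upward in this assay of a size comparable to, though less certain than, the measured one is therefore expected.

For compound 3 the expected step is a number 33 percentage points higher from compound 1 to compound 3 (beyond the scatter). Compound 3 is estimated at 65%, with a range from 38% to 90%.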

Compound 3, a percentage reported as inhibition, at one concentration (the size of the read-out at that concentration, not a potency): 51%
The estimate for compound 3 lay 14 percentage points above the measured number, within the range that was stated.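

In this assay, for the compounds shown here, methyl on an aromatic carbon para to a large group gives a number 19 percentage points higher from compound 1 to compound 3 (beyond the scatter), which is the first step of known size for this change and shows that the upward direction is not confined to one place on the ring. Compound 2, with methyl at a different place on the same ring, gives > 80%, which is a limit of the assay and not a number. Compound 3 gives 51%, but the gap between the two methyl places has no readable size: the limit of > 80% in this assay, at which 1 of the 3 values shown sits.

The compounds shown leave open whether another group at the para place, such as chlorine, methoxy or an amine, would move the number in this assay in the same direction, and whether a longer chain such as ethyl would raise it further than methyl does. They also leave open what methyl would do on the other aryl ring of the shared core, and whether two methyl groups on one ring would add up.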